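Swapping one azole for another on a weak inhibitor

This account rests on a few compounds, and the source may have more. Where it says the series, first, only, none or still open, it means among the compounds named here.

Compound 1, `Cc1noc(C)c1-c1cnc(N)c(Oc2ccc(C(=O)Nc3cccc(Cl)n3)cc2)n1`: 64100 nM
Compound 2, `Cc1noc(C)c1-c1cnc(N)c(Sc2ccc(C(=O)Nc3ccc(Cl)cc3)cc2)n1`: a limit, > 100000 nM

Both compounds were tested in a functional assay on U-87MG ATCC cells for inhibition, with U-87 MG (Homo sapiens) as the target, read by MTT assay, with a stated time of 72 h; a lower number here means a stronger inhibitor, a higher number a weaker inhibitor. Compound 1 gives 64100 nM, a weak result. Compound 2 gives no number at all: its result is the limit of > 100000 nM in this assay, at which 1 of the 2 values shown sits. In this assay, from the compounds shown here alone, compound 2 therefore stands at a limit, and how far it lies past that limit is unknown. Within the data shown here, no step between the two measured compounds can be described, since they differ in more than one place; all that can be said is that both sit at the weak end.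

Compound 3, `Cn1cc(-c2cnc(N)c(Sc3ccc(C(=O)Nc4ccc(Cl)cc4)cc3)n2)cn1`, has not yet been measured. It differs from compound 2 in one place: 1-methyl-1H-pyrazol-4-yl in place of 3,5-dimethyl-1,2-oxazol-4-yl on an aromatic carbon. The rest of the molecule is unchanged.

With compound 2 at a limit and compound 1 weak, a small change of this kind is expected to leave compound 3 in the same weak region. The expected step is a number no higher from compound 2 to compound 3 (the limit leaves the size open), none beyond the scatter, in no clear direction. Compound 3 is estimated at 100000 nM, with a range from 30000 nM to 300000 nM, and a real chance that only a limit is reported.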

Compound 3, half-maximal inhibitory concentration: > 100000 nM
Compound 3: a limit, no number (the forecaster's own chance of this, stated with the estimate: 60%); the middle value lies on the limit itself.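

In this assay compound 3 gives > 100000 nM which is a limit and not a number. Among these compounds, compound 2 also stands at a limit, so no step from compound 2 to compound 3 can be read: the limit of > 100000 nM in this assay, at which 2 of the 3 values shown sit. From the compounds shown here alone, how far past the limit each compound lies, and whether 1-methyl-1H-pyrazol-4-yl or 3,5-dimethyl-1,2-oxazol-4-yl gives the stronger inhibitor, stays open.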